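A few compounds are considered here, and "the series" means these few. Any claim that something is new, unique, unknown or untested is made for them only; others in the source may bear on it.

Working notes on the series.

Of the compounds shown here, two have been measured. Compound 1 `CC1(C(=O)NCCSc2nonc2/C(=N/O)Nc2ccc(F)c(C(F)F)c2)CCN1` gives 16 nM in an assay for inhibition of Indoleamine 2,3-dioxygenase 1 (Homo sapiens), read by fluorescence, with a stated time of 24 h; a higher number here means a weaker inhibitor, a lower number a stronger inhibitor. Among the compounds with values here, compound 2 `N#CCC(=O)NCCSc1nonc1/C(=N/O)Nc1ccc(F)c(C(F)F)c1` gives 6.5 nM in this assay, the lowest of the two numbers; the only neighbour is compound 1, and the step of a 2.5-fold lower number from compound 1 to compound 2 (0.39 log units; beyond the scatter) is beyond the scatter but modest.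

Compound 3 `CS(=O)(=O)CC(=O)NCCSc1nonc1/C(=N/O)Nc1ccc(F)c(C(F)F)c1` is not yet measured. It differs from compound 2 by methylsulfonyl in place of cyano on a saturated chain carbon bound to a carbonyl carbon. Within the data shown here, no measured step bears directly on this exchange; the one step known, a 2.5-fold lower number from compound 1 to compound 2 (0.39 log units; beyond the scatter), concerns a different part of the amide substituent and shows that a change at that position moves the number only modestly. The exchange in compound 3 is therefore expected to give at most a small step, if any beyond the scatter, with the direction uncertain.

For compound 3 the expected value in this assay is 9 nM, within 3 nM to 30 nM; the expected step is a 1.4-fold higher number from compound 2 to compound 3 (0.14 log units; within the scatter).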

Compound 3, half-maximal inhibitory concentration: 14 nM
For compound 3 the middle estimate is 1.6-fold (0.19 log units) below the measured one; the measured number falls inside the stated range.
By their numbers in this assay, from the lowest: compound 2; then compounds 3 and 1 (each within the scatter of the next).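

In this assay, the exchange on the saturated chain carbon bound to the carbonyl carbon now has a measured size: methylsulfonyl in place of cyano gives a 2.2-fold higher number from compound 2 to compound 3 (0.33 log units; beyond the scatter) and so, like the earlier step, is modest. Compound 2 thus keeps the lowest number of the three, with a step beyond the scatter to each of the others. The step of a 1.1-fold lower number from compound 1 to compound 3 (0.06 log units; within the scatter) also shows that the open-chain group of compound 3 and the group with the four-membered ring in compound 1 are not told apart here, although their atoms differ.

The compounds shown leave open whether the lower number of compound 2 belongs to the nitrile itself or to the short chain that carries it. As far as these compounds go, how an amine, a carboxylic acid or a longer chain on that carbon would compare also remains open. No other measurement bears on why these numbers differ.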